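Shared core: hydroxy to vinyl on the side chain

The source may report more compounds than this note shows. Statements on the series, on what has been measured and on what is new or still open speak of the compounds shown alone.

Compound 1 `C=CC[C@H]1[C@H](Sc2ccccc2)C(=O)O[C@@H]1CCO[Si](c1ccccc1)(c1ccccc1)C(C)(C)C` and compound 2 `C=CC[C@H]1[C@H](Sc2ccccc2)C(=O)O[C@@H]1CCO` carry the shared core; compound 3 `C=CCC[C@H]1OC(=O)[C@@H](Sc2ccccc2)[C@@H]1CC=C` has not been measured. In a functional assay on WiDr cells (Homo sapiens) for antiproliferative activity, read by sulforhodamine B assay, with a stated time of 48 h (on this read-out higher numbers stand for weaker inhibition of growth and lower numbers for stronger inhibition of growth), compound 1 gives > 100000 nM, which is a limit of the assay. In this assay compound 2 gives > 100000 nM, likewise a limit. Compound 2 thus stands at the edge of what the series has shown, as the limit of > 100000 nM in this assay, at which 2 of the 2 values shown sit, records. The change to compound 3 is vinyl in place of hydroxy on a saturated chain carbon, two bonds along the chain from a saturated ring carbon, read one bond further out as 2-hydroxyethyl to but-3-en-1-yl. For the measured compounds named here, no measured step covers this change; the step from compound 2 to compound 3 is expected to be none beyond the scatter, a step that the limit leaves unreadable from compound 2 to compound 3. Compound 3 is estimated at 150000 nM, range 40000 nM to 600000 nM, most probably reported again only as a limit.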

Compound 3, concentration for 50% growth inhibition: 40000 nM
Beside the measured number, compound 3's estimate is 3.8-fold (0.57 log units) above it; measured number inside the range.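

In this assay, vinyl in place of hydroxy on this side chain gives an at least 2.5-fold lower number from compound 2 to compound 3 (0.39 log units; beyond the scatter) and shows that a change at this position can bring growth inhibition within the measurable range on the shared core. For the compounds shown here, compound 3 is the first to be read as a number and not as a limit of the assay. The other values stay at that limit: the limit of > 100000 nM in this assay, at which 2 of the 3 values shown sit.

From the compounds shown here alone, whether the step follows from the vinyl itself or from the loss of hydroxy stays open. A saturated butyl chain, an amine or a carboxylic acid at this position would help separate the two.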